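The source may report more compounds than this note shows. Statements on the series, on what has been measured and on what is new or still open speak of the compounds shown alone.

Compound 1 `Cc1cc(NC(=O)Nc2ccc(C(C)(C)C)cc2)c2ccccc2n1`: 20000 nM
Compound 2 `COc1ccc(NC(=O)Nc2cc(C)nc3ccccc23)cc1OC`: > 25000 nM
Compound 3 `Cc1cc(NC(=O)Nc2cc(Cl)cc(Cl)c2)c2ccccc2n1`: > 25000 nM

Three ureas built on a shared core were tested in an ADME assay on BJ cells (Homo sapiens) for cytotoxicity, with a stated time of 72 h; on this read-out lower numbers stand for an effect already at smaller amounts and higher numbers for an effect only at larger amounts of compound. Compound 1 gives 20000 nM in this assay, and it is the only one of the three for which a number is reported at all. For compound 2 the result is a limit of the assay, > 25000 nM. Compound 3 likewise returns only a limit, > 25000 nM. Among the compounds with values here, two of the three results therefore rest at the limit of > 25000 nM in this assay, at which 2 of the 3 values shown sit, and compound 1 stands alone as the one measured value, itself not far from that limit.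

Compound 4 `Cc1cc(NC(=O)Nc2ccc(C(N)=O)cc2)c2ccccc2n1` has not yet been measured in this assay. It differs from compound 1 in one place: carbamoyl in place of tert-butyl on an aromatic carbon. Within the data shown here, no pair of measured compounds differs in a single place, so the data give no measured step to lean on. From compound 1 onward the change is expected to be small, if anything toward an effect only at larger amounts, and the expected step is a 1.4-fold higher number from compound 1 to compound 4 (0.15 log units; within the scatter), not clearly beyond the usual scatter. Compound 4 is accordingly estimated at 28000 nM, within a range from 12000 nM to 60000 nM, with a real chance that this assay reports only a limit for it.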

Compound 4, half-maximal effective concentration: > 25000 nM
Compound 4: no number, only a limit; the forecaster's own chance of this, stated with the estimate: 65%; the middle value lies beyond the limit too.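

Within the data shown here, this is the first comparison that differs in one place, and it concerns the group para to a large group: carbamoyl in place of tert-butyl on an aromatic carbon gives an at least 1.2-fold higher number from compound 1 to compound 4 (0.09 log units; that floor lies within the scatter) in this assay. The step has only a floor, since the result for compound 4 is a limit and not a number, so the data cannot separate a negligible change from a much larger one. What the pair does show is that the only number in the series does not survive this exchange, in which a group with no hydrogen-bond donor or acceptor gives way to one that carries one of each, and the series now rests mostly on the limit: the limit of > 25000 nM in this assay, at which 3 of the 4 values shown sit.

Going by these compounds, the true size of the step stays open, and so does whether the number seen with tert-butyl belongs to that group alone. On these data alone, it also remains open whether an amine, a carboxylic acid or a longer chain at this same position would give a measured number in this assay or would also end at the limit.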